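Swapping a methylphenyl for a chlorothiophene on the quinoline core

A few compounds are considered here, and "the series" means these few. Any claim that something is new, unique, unknown or untested is made for them only; others in the source may bear on it.

This short series shares one fused core carrying an aromatic group on the carbon next to the ring nitrogen and a carbonyl-linked group on the other ring. Compound 1 `COc1ccc(-c2cc(C(=O)OCc3ccccc3)c3ccccc3n2)cc1` carries a benzyl ester. Compound 2 `Cc1ccc(-c2cc(C(=O)N3CCC(Cc4ccccc4)CC3)c3ccccc3n2)cc1` carries a benzylpiperidine amide. Compound 3 `Cc1ccc([C@H](C)NC(=O)c2cc(-c3cccc(C)c3)nc3ccccc23)cc1` carries a methyl-substituted benzylic amide.

All three were tested in an ADME assay on HepG2 2.2.15 cells (Homo sapiens) for cytotoxicity, read by MTT assay, with stated times of 3 days and 7 days; a higher number here means that more compound is tolerated, a lower number that less compound is tolerated. In this assay compound 1 gives > 20000 nM, which is a limit of the assay and not a number. In this assay compound 2 gives > 20000 nM, again a limit rather than a measured number. In this assay compound 3 gives > 20000 nM, also a limit. For the measured compounds named here, compound 2 therefore stands where every value so far stands, at the limit of > 20000 nM in this assay, at which 3 of the 3 values shown sit, so no compound can be ranked against another.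

Compound 4 `O=C(c1cc(-c2ccsc2Cl)nc2ccccc12)N1CCC(Cc2ccccc2)CC1` differs from compound 2 in one place: 2-chlorothiophen-3-yl in place of 4-methylphenyl on an aromatic carbon, next to the ring nitrogen of the fused system.

Going by the values given here, with no measured step to lean on, the expected change in this assay is a step that the limit leaves unreadable from compound 2 to compound 4, nothing beyond the usual scatter. Compound 4 is therefore estimated at 30000 nM, with a range from 12000 nM to 80000 nM, most likely reported again as a limit.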

Compound 4, half-maximal cytotoxic concentration: > 20000 nM
Compound 4 gave a limit, no number; the forecaster's own chance of this, stated with the estimate: 80%; the middle value is on the limit's open side.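

In this assay compound 4 gives > 20000 nM, which is a limit and not a number. Compound 2 and compound 4 both rest on limits, so no step between them can be read: the limit of > 20000 nM in this assay, at which 4 of the 4 values shown sit.

The compounds shown leave open what concentration of any of them harms these cells, and whether 2-chlorothiophen-3-yl in place of 4-methylphenyl changes it.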